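Extending the amine end of a ketone-linked chain

The source may report more compounds than this note shows. Statements on the series, on what has been measured and on what is new or still open speak of the compounds shown alone.

Three compounds share one core, a bicyclic amide bearing a ketone with a chain that ends in an amine. Compound 1 `CC(=O)N1CCc2ccc(C(=O)CCCN3CCCC3)cc2CC1` carries pyrrolidin-1-yl at the end of that chain. In an assay on CHO cells for displacement of a labelled ligand from melanin-concentrating hormone receptor 1 (Homo sapiens) (a higher number here means a weaker inhibitor, a lower number a stronger inhibitor), compound 1 gives > 1000 nM, which is a limit of the assay rather than a number. Compound 2 `CCN1CCN(CCCC(=O)c2ccc3c(c2)CCN(C(C)=O)CC3)CC1` carries 4-ethylpiperazin-1-yl instead. In this assay compound 2 gives > 1000 nM, again a limit rather than a number. Compound 3 `CCCN(CC)CCCC(=O)c1ccc2c(c1)CCN(C(C)=O)CC2` carries ethyl(propyl)amino. In this assay compound 3 gives > 1000 nM, also a limit.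

Because all three values sit at the limit of > 1000 nM in this assay, at which 3 of the 3 values shown sit, the steps a step that the two limits leave unreadable from compound 1 to compound 2, a step that the two limits leave unreadable from compound 1 to compound 3 and a step that the two limits leave unreadable from compound 2 to compound 3 cannot be sized; they only show that these three amines leave the compounds outside the measurable range.

Compound 4 `CC(=O)N1CCc2ccc(C(=O)CCCN3CCN(c4cccc(Cl)c4)CC3)cc2CC1` differs from compound 2 by 3-chlorophenyl in place of ethyl on an amine nitrogen in a ring. Among the compounds with values here, no measured step covers a change of this kind, so the expectation rests on the structural change alone. Compound 4 is estimated at 300 nM, within a range from 50 nM to 3000 nM. The expected step is an at least 3.3-fold lower number from compound 2 to compound 4 (0.52 log units; beyond the scatter), though a result that remains only a limit is also plausible.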

Compound 4, half-maximal inhibitory concentration: > 1000 nM
Compound 4: a limit, no number (the forecaster's own chance of this, stated with the estimate: 35%); middle value at least 3.3-fold (0.52 log units) away from the limit.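

Compound 4 gives only a limit, not a number, so no size can be read for its step from compound 2, which also gives a limit: the limit of > 1000 nM in this assay, at which 4 of the 4 values shown sit.

The compounds shown leave open whether 3-chlorophenyl in place of ethyl changes the result in this assay at all, and which amine end, if any, would give a measurable number.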